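From 4-methylphenyl to 2-nitrophenyl: estimating cytotoxicity

A few compounds are considered here, and "the series" means these few. Any claim that something is new, unique, unknown or untested is made for them only; others in the source may bear on it.

- compound 1 `CC1=CC[C@@H]([C@@](C)(O)CCCC(C)(C)NC(=S)N/N=C\c2ccc(C)cc2)CC1` gives 52300 nM here
- compound 2 `COc1ccc(/C=N\NC(=S)NC(C)(C)CCC[C@](C)(O)[C@@H]2CC=C(C)CC2)cc1` gives 48500 nM here
- compound 3 `CC1=CC[C@@H]([C@@](C)(O)CCCC(C)(C)NC(=S)N/N=C\c2ccc(N(C)C)cc2)CC1` gives > 100000 nM here

All three values come from a functional assay on UACC-62 cells (Homo sapiens) for cytotoxicity, read by sulforhodamine B assay (on this read-out lower numbers stand for higher toxicity in this test and higher numbers for lower toxicity in this test), and the three compounds differ only in one group on an aromatic carbon. For compound 3 the result > 100000 nM is a limit and not a number. Compound 1 has one measured neighbour and stands level with it. That step reads a 1.1-fold lower number from compound 1 to compound 2 (0.03 log units; within the scatter) and so the pair cannot be told apart.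

Compound 4 `CC1=CC[C@@H]([C@@](C)(O)CCCC(C)(C)NC(=S)N/N=C\c2ccccc2[N+](=O)[O-])CC1` is not yet measured. It carries 2-nitrophenyl in place of 4-methylphenyl on a carbon with a double bond to nitrogen. Two further measured steps bear on this change, namely an at least 1.9-fold higher number from compound 1 to compound 3 (0.28 log units; that floor lies within the scatter) and an at least 2.0-fold higher number from compound 2 to compound 3 (0.31 log units; beyond the scatter) as well. From the compounds shown here alone, both rest on a limit (the limit of > 100000 nM in this assay, at which 1 of the 3 values shown sits) and so their full size stays open. For the measured compounds named here, no measured compound carries a nitro group, which makes all these steps a loose guide. Going by the values given here, the one firm pair is compound 2 at 48500 nM and compound 1 at 52300 nM with no real gap.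

In this assay the estimated step stays within the scatter (a 1.2-fold lower number from compound 1 to compound 4 (0.07 log units; within the scatter)). Compound 4 is expected at 45000 nM (estimated range 18000 nM to 100000 nM).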

Compound 4, concentration lethal to 50% of the cells: 49300 nM
The estimate for compound 4 lay 1.1-fold (0.04 log units) below the measured number; the range from low to high includes it.
By their numbers in this assay, from the lowest: compounds 2, 4 and 1 (each within the scatter of the next). At a limit, above all of these: compound 3.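

In this assay, replacing 4-methylphenyl with 2-nitrophenyl on a carbon with a double bond to nitrogen brings in a larger group with 2 hydrogen-bond acceptors, yet the reading reaches a 1.1-fold lower number from compound 1 to compound 4 (0.03 log units; within the scatter), and compound 4 also stands level with the methoxy compound at a 1.0-fold higher number from compound 2 to compound 4 (0.01 log units; within the scatter). For the compounds shown here, the earlier compounds showed only one level pair, whereas three different aromatic groups at this position, including the first with a nitro group, now cannot be told apart, and the level picture holds for compounds 1, 2 and 4 only. Compound 3, with 4-(dimethylamino)phenyl, is the one that may go against it, but its result is a limit, and an at least 2.0-fold lower number from compound 3 to compound 4 (0.30 log units; that floor lies within the scatter) is only a floor whose full size stays open: the limit of > 100000 nM in this assay, at which 1 of the 4 values shown sits.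

The compounds shown leave open whether 4-nitrophenyl would read the same as 2-nitrophenyl, and whether a carboxylic acid or a primary amine on the aromatic ring would shift the number beyond the scatter. They also leave open how far the reading depends on the rest of the molecule, for example on a shorter chain in the core of compound 1.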